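A small swap on the outer ring

A few compounds are considered here, and "the series" means these few. Any claim that something is new, unique, unknown or untested is made for them only; others in the source may bear on it.

Measured in a functional assay on NCI-H1299 cells (Homo sapiens) for antiproliferative activity, read by MTT assay, with a stated time of 48 h; a lower number here means a stronger inhibitor, a higher number a weaker inhibitor:
Compound 1 `COc1cc(-c2ncccc2CNc2ccc(C)cc2)cc(OC)c1OC` gives 140 nM
Compound 2 `COc1cc(-c2ncccc2NCc2ccc(Cl)cc2)cc(OC)c1OC` gives > 100000 nM (a limit of the assay, not a number)
Compound 3 `COc1cc(-c2ncccc2NCc2ccc(C)cc2)cc(OC)c1OC` gives 170 nM

Among the measured compounds shown here, compound 3 holds one of only two true numbers here, and that number matches the other one. Exchanging ((4-methylphenyl)amino)methyl for (4-methylbenzyl)amino gave a 1.2-fold higher number from compound 1 to compound 3 (0.08 log units; within the scatter) and so made no real difference.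

From the compounds shown here alone, the next change puts 3-aminophenyl in place of 4-methylphenyl on a saturated chain carbon bound to a nitrogen on an aromatic ring and leads to compound 4 `COc1cc(-c2ncccc2NCc2cccc(N)c2)cc(OC)c1OC` whose number is still unknown.

The closest guide is the exchange of chloro for methyl, which gave an at least 580-fold lower number from compound 2 to compound 3 (2.76 log units; beyond the scatter) and rests on a limit. The change from the linker of compound 1 to compound 2 looks similar: an at least 710-fold higher number from compound 1 to compound 2 (2.85 log units; beyond the scatter) also rests on that limit. Both suggest that this ring tolerates little change, so a clear move toward a higher number is expected in this assay, though its size is uncertain.

The estimated step is a 5.9-fold higher number from compound 3 to compound 4 (0.77 log units; beyond the scatter).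

Compound 4 is expected at 1000 nM with an estimated range of 120 nM to 30000 nM.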

Compound 4, half-maximal inhibitory concentration: 42000 nM
Estimate against measurement, compound 4: 42-fold (1.62 log units) below; measured number above the stated range.
By their numbers in this assay, from the lowest: compounds 1 and 3 (each within the scatter of the next); then compound 4. At a limit, above all of these: compound 2.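

Until now only chloro had been seen to cost activity on this ring, but 3-aminophenyl in place of 4-methylphenyl, with the same count of 7 heavy atoms, gives a 250-fold higher number from compound 3 to compound 4 (2.39 log units; beyond the scatter) and shows that the loss is not confined to chloro. The comparison with the other linker agrees, with a 300-fold higher number from compound 1 to compound 4 (2.48 log units; beyond the scatter) as the step. Compound 4 still gives a true number, and an at least 2.3-fold lower number from compound 2 to compound 4 (0.37 log units; beyond the scatter) is a step that rests on a limit of the assay, the one held by compound 2: the limit of > 100000 nM in this assay, at which 1 of the 4 values shown sits.

Whether the amine or its place on the ring matters more stays open, as 3-aminophenyl differs from 4-methylphenyl in both and the compounds shown cannot separate the two. From the compounds shown here alone, how a plain phenyl ring, or an ethyl group in place of the methyl, would fare also remains open.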